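The source may hold more compounds than are shown below. What is called first, only, known or untested is meant among the compounds shown, and "the series" means these compounds.

Compound 1, `O=C(c1ccc(C(F)(F)F)cc1)N1CCC(NS(=O)(=O)c2cc(S(=O)(=O)c3ccccc3)ccc2C(F)(F)F)CC1`, is measured in an assay on U2OS cells for inhibition of secreted frizzled-related protein 1 (Homo sapiens), read by a luciferase reporter, with a stated time of 18 h (a higher number here means that more compound is needed for the effect, a lower number that less compound is needed), where compound 1 gives 970 nM. That is the highest of the three numbers in hand. Nearest to it is compound 2, `CC(C)(O)CCN1CCC(NS(=O)(=O)c2cc(S(=O)(=O)c3ccccc3)ccc2C(F)(F)F)CC1`, which in this assay gives 630 nM; the step of a 1.5-fold lower number from compound 1 to compound 2 (0.19 log units; within the scatter) changes the same ring nitrogen that compound 4 will keep, and it stays within the scatter. Furthest from it is compound 3, `CC(C)(C)OC(=O)N1CCC(CC(=O)N2CCC(NS(=O)(=O)c3cc(S(=O)(=O)c4ccccc4)ccc3C(F)(F)F)CC2)CC1`, which in this assay gives 400 nM; the two values lie beyond the scatter of each other, and no single-point step connects these two compounds.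

Compound 4 is `O=C(CC1CCNCC1)N1CCC(NS(=O)(=O)c2cc(S(=O)(=O)c3ccccc3)ccc2C(F)(F)F)CC1`. It differs from compound 1 in one place: (piperidin-4-yl)methyl in place of 4-(trifluoromethyl)phenyl on a carbonyl carbon. Among the compounds with values here, the one measured step that bears on this change is the step from compound 1 to compound 2, where a replacement on the same part of the molecule moved the number only within the scatter. Compound 3 carries a related (piperidin-4-yl)methyl carbonyl group, though with a further group attached, and its value lies lower than that of compound 1. Taken together, a small move towards a lower number, not far beyond the scatter, is expected: a 1.9-fold lower number from compound 1 to compound 4 (0.29 log units; within the scatter). Compound 4 is therefore estimated at 500 nM, with a range from 200 nM to 1500 nM.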

Compound 4, half-maximal effective concentration: 210 nM
Compound 4: middle estimate off by 2.4-fold (0.38 log units), on the high side; low and high end bracket the measured number.
By their numbers in this assay, from the lowest: compounds 4, 3, 2 and 1 (each within the scatter of the next, the first and the last beyond it).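

Placing (piperidin-4-yl)methyl instead of 4-(trifluoromethyl)phenyl on the carbonyl carbon gives a step that clears the scatter (a 4.6-fold lower number from compound 1 to compound 4 (0.66 log units; beyond the scatter)), so at this place in this assay the six-membered aromatic ring of carbon only is not needed, and a non-aromatic ring holding a nitrogen serves at least as well. The ring nitrogen of the shared core also gives a step beyond the scatter when ((piperidin-4-yl)methyl)carbonyl stands on it in place of 3-hydroxy-3-methylbutyl (a 3.0-fold lower number from compound 2 to compound 4 (0.48 log units; beyond the scatter)), while hydrogen in place of tert-butoxycarbonyl on the outer ring nitrogen stays within the scatter (a 1.9-fold lower number from compound 3 to compound 4 (0.28 log units; within the scatter)), so that nitrogen can carry either group without a difference that can be told apart here. No measurement in hand gives a reason for any of these steps.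

The compounds shown leave open whether the outer ring nitrogen itself matters, which a cyclohexylmethyl group on the same carbonyl carbon, with carbon in place of that nitrogen, would test. A piperidin-4-yl group set directly on the carbonyl carbon, or a longer chain before the ring, would show how much the link of the group counts.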